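The compounds below may be only part of what the source reports. "The series", "measured", "known", "first", "only" and "open" are said of these compounds alone.

Among the compounds with values here, two pairs of compounds share one small alteration, and only one pair has been measured on both sides. Compound 1 `COc1cc2c(cc1C)NC(=O)/C2=C/c1c(Cl)n(C)c2cc(C)c(OC)cc12` and compound 2 `COc1cc2c(cc1C)N(C)C(=O)/C2=C/c1c(Cl)n(C)c2cc(C)c(OC)cc12` were tested in a functional assay on NSCLC cells (Homo sapiens) for inhibition, with a stated time of 48 h; on this read-out higher numbers stand for weaker inhibition of growth and lower numbers for stronger inhibition of growth. Compound 1 gives 97700 nM, and compound 2 gives 69200 nM. The change between them is methyl in place of hydrogen on an amide-type nitrogen in a ring. The step is a 1.4-fold lower number from compound 1 to compound 2 (0.15 log units; within the scatter), so in this pair the added methyl left the result essentially where it was.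

Compound 3 `CN(C)c1ccc2[nH]c(Cl)c(/C=C3/C(=O)Nc4ccc(O)cc43)c2c1` rests on a different core; the difference between the two cores is not broken down here. In this assay compound 3 gives 31600 nM, the lowest of the three numbers, and its gap to compound 2 and to compound 1 lies beyond the usual scatter in each case.

Compound 4 `CN(C)c1ccc2[nH]c(Cl)c(/C=C3/C(=O)N(C)c4ccc(O)cc43)c2c1` has not yet been measured in this assay. It differs from compound 3 by methyl in place of hydrogen on an amide-type nitrogen in a ring, the same change at the same place as between compound 1 and compound 2. Within the data shown here, for compound 4 the expected step is a 1.3-fold lower number from compound 3 to compound 4 (0.10 log units; within the scatter), because the one measured example of this change was a 1.4-fold lower number from compound 1 to compound 2 (0.15 log units; within the scatter). That expectation leans on a single pair built on another core, so it is weakly supported. For compound 4 the value expected in this assay is 25000 nM, with a likely range from 10000 nM to 60000 nM.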

Compound 4, concentration for total growth inhibition: 46800 nM
Beside the measured number, compound 4's estimate is 1.9-fold (0.27 log units) below it; measured number inside the range.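

In this assay, methyl in place of hydrogen on the amide-type nitrogen of the other core gives a 1.5-fold higher number from compound 3 to compound 4 (0.17 log units; within the scatter), so here too the added methyl left the result essentially where it was. On paper the two steps point in opposite directions, but each is small enough to be ordinary variation between repeated measurements, and the gap between them is no larger than two such steps can show by chance: the same change on two cores in this assay, a 1.4-fold lower number (0.15 log units; within the scatter) from compound 1 to compound 2 and a 1.5-fold higher number (0.17 log units; within the scatter) from compound 3 to compound 4, 2.1-fold (0.32 log units) apart, within the scatter of two such steps. This shows that the change made no readable difference on either core in this assay, so treating it as a change of little consequence carries across these two cores, but it does not prove that the methyl has no effect at all, and two pairs say nothing firm about any further core.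

Only hydrogen and methyl appear on this nitrogen among the compounds shown, which leaves open whether an ethyl group, a longer chain ending in an amine, or a chain carrying a carboxylic acid would move the number beyond the usual scatter. Also open, from the compounds shown here alone, is whether the methyl would stay just as silent on a third core.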